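Swapping methyl for carbamoyl on compound 3

This account rests on a few compounds, and the source may have more. Where it says the series, first, only, none or still open, it means among the compounds named here.

Results so far in an ADME assay on cells (Hepatocyte, Rattus norvegicus) for metabolic stability, read by LC-MS, with a stated time of 60 min (a higher number here means that more of the compound is left, a lower number that less of the compound is left), are:
- compound 1 `C[C@@H]1CC(c2cnc3c(C#N)nn([C@H](C)c4ccc(Cl)cc4Cl)c3n2)=CC[C@@H]1N1CCC[C@H]1CO` gives 32% remaining
- compound 2 `C[C@@H]1CC(c2cnc3c(C#N)nn([C@H](C)c4ccc(Cl)cc4Cl)c3n2)=CC[C@@H]1N1CCC[C@H]1C(C)(C)O` is recorded as "not determined" (no result reported)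
- compound 3 `C[C@@H]1CC(c2cnc3c(C#N)nn([C@H](C)c4ccc(Cl)cc4Cl)c3n2)=CC[C@@H]1N1CCC[C@H]1C` gives 72% remaining

Compound 3 holds the higher of the two available numbers. The next compound, compound 4 `C[C@@H]1CC(c2cnc3c(C#N)nn([C@H](C)c4ccc(Cl)cc4Cl)c3n2)=CC[C@@H]1N1CCC[C@H]1C(N)=O`, differs from it as follows: carbamoyl in place of methyl on a saturated ring carbon. Going by the values given here, one measured step bears on this, a number 40 percentage points higher from compound 1 to compound 3 (beyond the scatter), a large rise when hydrogen replaced hydroxy on a saturated chain carbon. Carbamoyl is not hydroxy, so that step is only a loose guide, read in reverse. A smaller fall than that step is therefore expected, with an estimated a number 17 percentage points lower from compound 3 to compound 4 (beyond the scatter) in this assay as the likely move. The estimate for compound 4 is 55% (range 30% to 78%) remaining.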

Compound 4, percent of the compound remaining: 71%
Estimate against measurement, compound 4: 16 percentage points below, and the stated range covers the measured number.
By their numbers in this assay, from the lowest: compound 1; then compounds 4 and 3 (each within the scatter of the next).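

In this assay, the 2-methylpyrrolidin-1-yl group can give way to 2-carbamoylpyrrolidin-1-yl with no change beyond the scatter, a number 1 percentage points lower from compound 3 to compound 4 (within the scatter). So on this saturated ring carbon, the larger carbamoyl group, with its hydrogen-bond donor and acceptor, keeps the number where methyl had it, whereas hydroxymethyl does not, a number 39 percentage points higher from compound 1 to compound 4 (beyond the scatter). Nothing available explains the gap between carbamoyl and hydroxymethyl. On these data alone, whether a carboxylic acid or an aminomethyl group on the same carbon would stay with compound 3 and compound 4 or fall toward compound 1 remains open.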